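A few compounds are considered here, and "the series" means these few. Any claim that something is new, unique, unknown or untested is made for them only; others in the source may bear on it.

In a functional assay on HepG2 cells (Homo sapiens) for antiproliferative activity, read by XTT assay, with a stated time of 72 h (on this read-out lower numbers stand for stronger inhibition and higher numbers for weaker inhibition), compound 2 `COc1ncnc2c1c(-c1ccccc1)cn2[C@@H]1O[C@H](CO)[C@@H](O)[C@H]1O` gives only a limit, > 20000 nM. Its close relative compound 1 `CSc1ncnc2c1c(-c1ccccc1)cn2[C@@H]1O[C@H](CO)[C@@H](O)[C@H]1O` likewise reaches only a limit in this assay, > 20000 nM. The single measured step, a step that the two limits leave unreadable from compound 1 to compound 2, is therefore one whose size cannot be read, as shown by the limit of > 20000 nM in this assay, at which 2 of the 2 values shown sit. Compound 3 `COc1ncnc2c1c(-c1ccco1)cn2[C@@H]1O[C@H](CO)[C@@H](O)[C@H]1O` is the next compound to be tested; it differs from compound 2 by furan-2-yl in place of phenyl on an aromatic carbon. Among the measured compounds shown here, no measured step touches this change: the one step known alters a different group, and even that one left no readable size. With compound 2 sitting at a limit, neither a direction nor a size of step in this assay can be drawn from the numbers shown. Compound 3 is therefore expected to land near the limit as well, estimated at 25000 nM with a range from 8000 nM to 80000 nM. The step this implies, a step that the limit leaves unreadable from compound 2 to compound 3, is an expectation only.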

Compound 3, half-maximal inhibitory concentration: 300 nM
The estimate for compound 3 lay 83-fold (1.92 log units) above the measured number; the whole stated range lies above it.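

In this assay, this carbon of the five-membered aromatic ring turns out to matter: furan-2-yl in place of phenyl gives an at least 66-fold lower number from compound 2 to compound 3 (1.82 log units; beyond the scatter). The step between compound 1 and compound 2 cannot be read, so the earlier compounds showed no effect of any change, and compound 3 is the only one shown with a value that is not a limit: the limit of > 20000 nM in this assay, at which 2 of the 3 values shown sit. The swap exchanges a six-membered carbon ring for a five-membered ring with one oxygen, and that is enough to give a measurable value in this cell test.

On these data alone, it remains open whether the ring oxygen or the smaller ring accounts for the step, and a thiophene ring at this place could help separate the two. Also open, as far as these compounds go, is whether furan-2-yl would give a similar step with methylsulfanyl in place of methoxy.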